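A few compounds are considered here, and "the series" means these few. Any claim that something is new, unique, unknown or untested is made for them only; others in the source may bear on it.

Measured so far:

compound 1, `Cc1nnc(SCC(=O)N/N=c2/scc(-c3ccc(F)cc3)n2-c2ccccc2)s1`, 37.4%
compound 2, `COc1ccc(-c2cs/c(=N/NC(=O)CSc3ncccn3)n2-c2ccccc2)cc1`, 66.5%

The read-out is a functional assay on C6 cells (Rattus norvegicus) for cytotoxicity, read by MTT assay, with a stated time of 24 h, tested at 50 ug/mL; a lower number here means a stronger effect, a higher number a weaker effect of the compound at the concentration tested. Two compounds have numbers. Compound 2 stands highest of the two; its nearest neighbour is compound 1, whose value lies lower by a margin beyond the usual scatter, so compound 2 shows the weaker effect of the pair at the concentration tested. For the measured compounds named here, no pair among the measured compounds differs in a single place, so no measured step is available to lean on.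

The next compound, compound 3, `COc1ccc(-c2cs/c(=N/NC(=O)CSc3nnc(C)s3)n2-c2ccccc2)cc1`, is not yet measured in this assay. It differs from compound 2 in one place: 5-methyl-1,3,4-thiadiazol-2-yl in place of pyrimidin-2-yl on a sulfur. Compound 1 also carries the 5-methyl-1,3,4-thiadiazol-2-yl group on that sulfur and gives the lower of the two numbers, but compound 1 and compound 3 are not a single-change pair, so this is only a hint. The step from compound 2 to compound 3 is expected to be downward by a moderate amount, estimated at a number 14.5 percentage points lower from compound 2 to compound 3 (beyond the scatter), with the possibility that it stays within the scatter. Compound 3 is expected to give about 52%, with a range from 32% to 72%.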

Compound 3, a percentage reported as activity, at one concentration (the size of the read-out at that concentration, not a potency): 31.5%
Beside the measured number, compound 3's estimate is 20.5 percentage points above it, outside the stated range (below it).
By their numbers in this assay, from the lowest: compounds 3 and 1 (each within the scatter of the next); then compound 2.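

In this assay, for the compounds shown here, the exchange on the sulfur gives a number 35 percentage points lower from compound 2 to compound 3 (beyond the scatter), the first single-change evidence that the group at this position can shift the read-out at the concentration tested, here with methoxy on the aromatic carbon. Methoxy in place of fluoro on the aromatic carbon gives a number 5.9 percentage points lower from compound 1 to compound 3 (within the scatter), so with 5-methyl-1,3,4-thiadiazol-2-yl on the sulfur, this aromatic exchange is not resolved in this assay. Going by these compounds alone, nothing measured so far accounts for the large step on the sulfur.

As far as these compounds go, it remains open whether the exchange of pyrimidin-2-yl for 5-methyl-1,3,4-thiadiazol-2-yl gives a step of similar size with fluoro on the aromatic carbon, and whether the ring itself or its methyl group carries the step. An amine in place of that methyl, or a carboxylic acid on the same ring, would test how much this position tolerates, while a single concentration leaves the potency of all three compounds unresolved.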